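Amide to Urea on the Anilide Arm of Compound 1

This account rests on a few compounds, and the source may have more. Where it says the series, first, only, none or still open, it means among the compounds named here.

This account follows three measured compounds and one that awaits measurement. Compound 1, `COc1cc(-c2nn(-c3cccc(NC(=O)c4cccc(C(F)(F)F)c4)c3)cc2-c2ccncc2)ccc1Cl`, was tested in a functional assay on HCC 2998 cells (Homo sapiens) for inhibition, read by sulforhodamine B assay, with a stated time of 48 h (on this read-out higher numbers stand for weaker inhibition of growth and lower numbers for stronger inhibition of growth), where compound 1 gives 2240 nM. Two ureas bearing a hydroxy group in place of the methoxy group on the shared core were run alongside it: compound 2, `O=C(Nc1cccc(-n2cc(-c3ccncc3)c(-c3ccc(Cl)c(O)c3)n2)c1)Nc1cc(C(F)(F)F)cc(C(F)(F)F)c1`, gives 1030 nM, and compound 3, `O=C(Nc1cccc(-n2cc(-c3ccncc3)c(-c3ccc(Cl)c(O)c3)n2)c1)Nc1ccc(Cl)c(C(F)(F)F)c1`, gives 1060 nM. Among these three numbers compound 1 stands highest; both compound 3 and compound 2 lie below it by margins beyond the usual scatter, so compound 1 shows the weakest growth inhibition of the three.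

Compound 4, `COc1cc(-c2nn(-c3cccc(NC(=O)Nc4ccc(Cl)c(Cl)c4)c3)cc2-c2ccncc2)ccc1Cl`, keeps the methoxy-bearing core of compound 1 and differs from it in one place: (3,4-dichlorophenyl)amino in place of 3-(trifluoromethyl)phenyl on a carbonyl carbon. Within the data shown here, no pair of measured compounds differs by only this change, so its size can only be inferred. Because compound 2 gives 1030 nM and compound 3 gives 1060 nM, both ureas sitting below compound 1, a moderate move toward stronger inhibition is expected, though both also carry the hydroxy group, which compound 4 lacks. The expected step of a 1.7-fold lower number from compound 1 to compound 4 (0.24 log units; within the scatter) is therefore modest. Compound 4 is estimated at 1300 nM, within a range of 500 nM to 3500 nM.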

Compound 4, concentration for 50% growth inhibition: 1560 nM
For compound 4 the middle estimate is 1.2-fold (0.08 log units) below the measured one; the measured number falls inside the stated range.
By their numbers in this assay, from the lowest: compounds 2, 3, 4 and 1 (each within the scatter of the next, the first and the last beyond it).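

In this assay, among these compounds, the step of a 1.4-fold lower number from compound 1 to compound 4 (0.16 log units; within the scatter) gives the first reading of this change with the methoxy-bearing core held fixed, which compounds 2 and 3 could not give, as they also carry the hydroxy group. At this position on the carbonyl carbon, (3,4-dichlorophenyl)amino can therefore take the place of 3-(trifluoromethyl)phenyl, bringing in an amide-type nitrogen with its hydrogen-bond donor, without a shift in growth inhibition that stands clear of the scatter. The swap alters the linkage and the ring substituents together, so this single step cannot assign any part of it to either one.

The compounds shown leave open how the urea linkage would read with 3-(trifluoromethyl)phenyl kept on its nitrogen, and how the hydroxy group would read on compound 4 itself. They also leave open whether this position accepts something other than a substituted phenyl ring, such as a morpholine or a ring bearing a carboxylic acid.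

No measurement offered here accounts for the size of this step.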